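The compounds below may be only part of what the source reports. "The series", "measured", "known", "first", "only" and "open" are said of these compounds alone.

Measured so far:
Compound 1, `O=C(NCCCCC(c1ccc(F)cc1)c1ccc(F)cc1)Nc1ccc(Cl)cc1` — 82%
Compound 2, `O=C(NCCCCC(c1ccc(F)cc1)c1ccc(F)cc1)Nc1ccc(I)cc1` — 24%
Compound 3, `CC(=O)Nc1cc(NC(=O)NCCCCC(c2ccc(F)cc2)c2ccc(F)cc2)ccc1Cl` — 76%

In an ADME assay on isolated protein for inhibition of sodium-dependent dopamine transporter (Homo sapiens), tested at 10 uM (a higher number here means more inhibition at the concentration tested (going by the name of the read-out), a lower number less inhibition), compound 3 stands second highest of the three numbers. Its nearest neighbour is compound 1, whose value sits higher, but a number 6 percentage points lower from compound 1 to compound 3 (within the scatter) lies within the scatter, so the two are not separable. The furthest number belongs to compound 2, and a number 52 percentage points higher from compound 2 to compound 3 (beyond the scatter) is a large step.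

Compound 4, `Cc1ccc(NC(=O)NCCCCC(c2ccc(F)cc2)c2ccc(F)cc2)cc1C`, has not yet been measured. The change from compound 3 is 3,4-dimethylphenyl in place of 3-acetamido-4-chlorophenyl on an amide-type nitrogen.

Going by the values given here, two measured steps bear on this. The step of a number 6 percentage points lower from compound 1 to compound 3 (within the scatter) shows that acetamido in place of hydrogen on an aromatic carbon leaves the number essentially where it was, so the loss of the acetamido group in compound 4 is not expected to matter much on its own. The step of a number 58 percentage points lower from compound 1 to compound 2 (beyond the scatter) shows, however, that the group on the aromatic carbon that carries the halogen can move the number a great deal. Among the compounds with values here, compound 4 carries methyl groups and no halogen, a situation for which no measured compound exists, so the direction is uncertain. Compound 4 is therefore expected to give 62% in this assay, within the range 35% to 85%, which amounts to an expected step of a number 14 percentage points lower from compound 3 to compound 4 (beyond the scatter).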

Compound 4, a percentage reported as inhibition, at one concentration (the size of the read-out at that concentration, not a potency): 79%
The estimate for compound 4 lay 17 percentage points below the measured number, and the stated range covers the measured number.
By their numbers in this assay, from the lowest: compound 2; then compounds 3, 4 and 1 (each within the scatter of the next).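

Compound 4 shows that this position on the amide-type nitrogen can carry 3,4-dimethylphenyl, a group without chlorine, nitrogen or oxygen, and stay in the upper group of this assay: the result is a number 3 percentage points higher from compound 3 to compound 4 (within the scatter) and a number 3 percentage points lower from compound 1 to compound 4 (within the scatter), so compound 4 cannot be told apart from either. A halogen on the ring is therefore not required for a high number among these compounds, and compound 2 alone goes against the upper group, as a number 55 percentage points higher from compound 2 to compound 4 (beyond the scatter) makes plain. Nothing measured here accounts for why compound 2 stands apart from the others.

Going by these compounds, it remains open whether the low number belongs to 4-iodophenyl alone or would also appear with 4-bromophenyl. Also open, on these data alone, is how a ring carrying an amine or a carboxylic acid would behave at this position.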